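Phenyl in place of pyridin-3-yl: working notes

The source may report more compounds than this note shows. Statements on the series, on what has been measured and on what is new or still open speak of the compounds shown alone.

Among the measured compounds shown here, in a functional assay on KB-VIN10 cells (Homo sapiens) for inhibition, with a stated time of 72 h (on this read-out lower numbers stand for stronger inhibition and higher numbers for weaker inhibition), compound 1 `COc1ccc(-c2cccc3c2N(S(=O)(=O)c2ccc(OC)cc2)CC3)cc1` gives 352 nM while compound 2 `COc1ccc(S(=O)(=O)N2CCc3cccc(-c4cccnc4)c32)cc1` gives 84.5 nM as the lower of the two numbers so far. The next change leads to compound 3 `COc1ccc(S(=O)(=O)N2CCc3cccc(-c4ccccc4)c32)cc1` with phenyl in place of pyridin-3-yl on an aromatic carbon. For the measured compounds named here, one measured step bears on this, pyridin-3-yl in place of 4-methoxyphenyl, which is modest and beyond the scatter. Going by the values given here, compound 3 keeps a ring of carbon only, as compound 1 does, but lacks the methoxy group, and no measurement yet separates these two features. Resting on a 4.2-fold lower number from compound 1 to compound 2 (0.62 log units; beyond the scatter) as the only guide, a smaller step towards a higher number is expected in this assay and it may not clear the scatter. The expected change is an estimated 2.2-fold higher number from compound 2 to compound 3 (0.35 log units; beyond the scatter) on this basis. Compound 3 is estimated at 190 nM (range 60 nM to 500 nM).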

Compound 3, half-maximal inhibitory concentration: 107 nM
For compound 3 the middle estimate is 1.8-fold (0.25 log units) above the measured one, within the range that was stated.
By their numbers in this assay, from the lowest: compounds 2 and 3 (each within the scatter of the next); then compound 1.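

In this assay, the ring nitrogen of pyridin-3-yl makes no difference that can be read at this aromatic carbon: a 1.3-fold higher number from compound 2 to compound 3 (0.10 log units; within the scatter), so phenyl and pyridin-3-yl are not told apart here. Among the compounds shown here, with hydrogen in place of methoxy, the methoxy group is separated from the ring nitrogen for the first time, and a 3.3-fold lower number from compound 1 to compound 3 (0.52 log units; beyond the scatter), which places the earlier gain with loss of the methoxy group rather than with the change of ring. No measurement on hand explains either step.

Still open, as far as these compounds go, is whether a group other than methoxy on the phenyl ring, such as an amine or a carboxylic acid, would shift the number in either direction. Also open, from the compounds shown here alone, is whether a saturated ring such as morpholine could take the place of the aromatic ring at this carbon.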